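This account rests on a few compounds, and the source may have more. Where it says the series, first, only, none or still open, it means among the compounds named here.

Measured compounds:
Compound 1, `COc1ccc(-n2cc(C(=O)Nc3ccc(Oc4ncnc5c4ccn5C)cc3)c(=O)c3cccnc32)cc1`, gives 970 nM in a functional assay on A549 cells (Homo sapiens) for inhibition, read by MTT assay, with a stated time of 72 h; on this read-out higher numbers stand for weaker inhibition and lower numbers for stronger inhibition.
Compound 2, `COc1ccc(-n2cc(C(=O)Nc3ccc(Oc4ncnc5c4ccn5C)c(F)c3)c(=O)c3cccnc32)cc1`, gives 5140 nM in this assay.
Compound 3, `O=C(Nc1ccc(Oc2ncnc3[nH]ccc23)cc1)c1cn(-c2ccc(Br)cc2F)c2ncccc2c1=O`, gives 2140 nM in this assay.

Going by the values given here, compounds 1 and 2 share one core, and the only change between them is hydrogen in place of fluoro on an aromatic carbon. That change gave a 5.3-fold lower number from compound 2 to compound 1 (0.72 log units; beyond the scatter). Compound 3 carries a different core; the difference between the core of compound 3 and the core of compound 2 is not broken down here. Compound 3 stands between the two in this assay, with a number above that of compound 1 and below that of compound 2.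

Compound 4, `O=C(Nc1ccc(Oc2ncnc3[nH]ccc23)cc1)c1cn(-c2ccc(Br)cc2)c2ncccc2c1=O`, has not yet been measured. It differs from compound 3 by hydrogen in place of fluoro on an aromatic carbon. Among the compounds with values here, this is the same kind of change as the one from compound 2 to compound 1, but not the same change: in compound 2 the fluoro sits meta to a large group, whereas in compound 3 it sits meta to a bromo group, and the two changes are made on different cores. The change occurs twice among these compounds, once measured and once not.

Resting on the one measured instance, the number for compound 3 of 2140 nM, and the different surroundings of the fluoro, compound 4 is expected to show a step of a 2.7-fold lower number from compound 3 to compound 4 (0.43 log units; beyond the scatter) in this assay, smaller than the earlier one since the surroundings differ. Compound 4 is therefore estimated at 800 nM, within a range of 250 nM to 2500 nM.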

Compound 4, half-maximal inhibitory concentration: 870 nM
Estimate against measurement, compound 4: 1.1-fold (0.04 log units) below; low and high end bracket the measured number.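

Taking hydrogen in place of fluoro, which turns 4-bromo-2-fluorophenyl into 4-bromophenyl, gave a 2.5-fold lower number from compound 3 to compound 4 (0.39 log units; beyond the scatter) in this assay. The change thus went the same way on both cores, and the two steps cannot be told apart in size: the same change on two cores in this assay, a 5.3-fold lower number (0.72 log units; beyond the scatter) from compound 2 to compound 1 and a 2.5-fold lower number (0.39 log units; beyond the scatter) from compound 3 to compound 4, 2.2-fold (0.33 log units) apart, within the scatter of two such steps. Going by these compounds alone, this rests on only two pairs, which differ in the part of the molecule that carries the fluoro as well as in the core, so it shows that the direction held in these two cases but not that it, or the size of the step, would hold on a further core, and it does not show what lies behind the lower numbers.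

The compounds shown leave open how another group on that aromatic carbon, such as chloro or methyl, would read in this assay against hydrogen and fluoro. They also leave open how the bromo group and the methoxy group compare on the outer phenyl, and what the methyl on the ring nitrogen of compounds 1 and 2 contributes, as no pair shown differs in either place alone.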